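From Pyrrole to Triazole on the Amide-Bound Methylene

The compounds below may be only part of what the source reports. "The series", "measured", "known", "first", "only" and "open" are said of these compounds alone.

Three measured compounds share a common core and are compared in an assay on HEK293 cells for agonist activity at transient receptor potential cation channel subfamily M member 8 (Homo sapiens), read by fluorescence and calcium flux, with a stated time of 15 min; a lower number here means that less compound is needed, a higher number that more compound is needed for the effect. Compound 1 `CCN(Cc1cc[nH]c1)C(=O)COc1ccc(C)cc1` gives 21800 nM in this assay , the highest of the two numbers reported. Compound 2 `CCN(Cc1cccs1)C(=O)COc1ccccc1` reaches 1400 nM in this assay , a difference from compound 1 that lies beyond the scatter. Compound 3 `CCN(Cc1cccs1)C(=O)C[C@@H](O)c1ccccc1` is reported in this assay as "not active" (no number reported), with no number given. Compound 4 `CCN(Cc1c[nH]nn1)C(=O)COc1ccc(C)cc1` has not yet been measured; it differs from compound 1 by 1H-1,2,3-triazol-4-yl in place of 1H-pyrrol-3-yl on a saturated chain carbon bound to an amide-type nitrogen. Going by the values given here, no pair of measured compounds shows what this exchange does, so nothing here grounds a firm direction. A modest step of a 1.4-fold higher number from compound 1 to compound 4 (0.14 log units; within the scatter) toward a higher number is expected, with wide uncertainty. Compound 4 is therefore estimated at 30000 nM, within 8000 nM to 100000 nM.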

Compound 4, half-maximal effective concentration: 31100 nM
Compound 4: the middle estimate sits 1.0-fold (0.02 log units) below what was measured, within the range that was stated.
By their numbers in this assay, from the lowest: compound 2; then compounds 1 and 4 (each within the scatter of the next).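

In this assay the step of a 1.4-fold higher number from compound 1 to compound 4 (0.15 log units; within the scatter) shows that, on a saturated chain carbon bound to an amide-type nitrogen, a five-membered aromatic ring with 3 hetero atoms can stand in place of one with 1 hetero atom without a change that rises above the scatter. Going by these compounds alone, this is the first direct reading of this exchange at this position. Nothing measured here explains the result.

From the compounds shown here alone, whether a simple amine, a carboxylic acid or a longer chain at this place would give a similar number stays open.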